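From Ester to Amide on a Shared Core

The compounds below may be only part of what the source reports. "The series", "measured", "known", "first", "only" and "open" are said of these compounds alone.

Compound 1 `COC(=O)/C=C/c1ccc2noc(-c3ccccc3)c2c1`: 1580 nM
Compound 2 `Cc1ccc(-c2onc3ccc(/C=C/C(=O)O)cc23)cc1`: 6510 nM
Compound 3 `Cc1cccc(-c2onc3ccc(/C=C/C(=O)O)cc23)c1`: 290 nM

In an assay for inhibition of inositol hexakisphosphate kinase 2 (Homo sapiens), read by colorimetric assay, coupled enzyme assay and malachite green, with a stated time of 120 min, in the presence of a further agent that is not named here (a higher number here means a weaker inhibitor, a lower number a stronger inhibitor), compound 1 stands second highest of the three numbers: compound 2 gives a higher number, compound 3 a lower one. Among the compounds with values here, the only step between compounds that differ in one place is a 22-fold lower number from compound 2 to compound 3 (1.35 log units; beyond the scatter), and it concerns a different part of the molecule. Compound 4 `CNC(=O)c1ccc2noc(-c3ccccc3)c2c1` differs from compound 1 by methylcarbamoyl in place of 2-(methoxycarbonyl)ethenyl on an aromatic carbon. Within the data shown here, no measured step bears on this change, so its size and direction in this assay are open. Compound 4 is therefore expected to give 2500 nM, in a wide range from 500 nM to 12000 nM. This estimate means a step of a 1.6-fold higher number from compound 1 to compound 4 (0.20 log units; within the scatter), expected to be modest.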

Compound 4, half-maximal inhibitory concentration: 2120 nM
The estimate for compound 4 lay 1.2-fold (0.07 log units) above the measured number; the measured number falls inside the stated range.
By their numbers in this assay, from the lowest: compound 3; then compounds 1 and 4 (each within the scatter of the next); then compound 2.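

In this assay, methylcarbamoyl in place of 2-(methoxycarbonyl)ethenyl gives a 1.3-fold higher number from compound 1 to compound 4 (0.13 log units; within the scatter) and so shows that this position on the shared core accepts both groups without a change beyond the scatter. The entering group is the one with a hydrogen-bond donor, and it has no double bond between carbons, yet the two numbers cannot be told apart. Nothing available explains this result. Going by these compounds, it remains open whether an amine, or a longer chain on the amide nitrogen, would move the number beyond the scatter at this position, and whether the step seen with 3-methylphenyl carries over to the amide.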